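A Dimethylamino Group Replaces Methyl on a Shared Core

The source may report more compounds than this note shows. Statements on the series, on what has been measured and on what is new or still open speak of the compounds shown alone.

Compound 1 `Cc1ccc(C(=O)NN2C(=O)NC3(CC3(C)C)C2=O)cc1` and compound 2 `COc1ccc(C(=O)NN2C(=O)NC3(CC3(C)C)C2=O)cc1` share one core and differ only in the group carried on an aromatic carbon. In a functional assay on the whole organism (Hindlimb) for inhibition, with Mus musculus as the target, with a stated time of 0.5 h (on this read-out lower numbers stand for an effect already at smaller amounts and higher numbers for an effect only at larger amounts of compound), compound 1 gives 100 mg/kg, and in this assay compound 2 gives 100 mg/kg. For the measured compounds named here, the single measured step, no change at the digits printed from compound 1 to compound 2 (within the scatter), shows that placing methoxy in place of methyl on an aromatic carbon left the dose where it was, within the scatter. On the numbers at hand compound 1 therefore stands level with compound 2.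

Compound 3 `CN(C)c1ccc(C(=O)NN2C(=O)NC3(CC3(C)C)C2=O)cc1` has the same core with yet another group at that aromatic carbon. Its change from compound 1 is dimethylamino in place of methyl on an aromatic carbon. Going by the values given here, the only measured step that bears on it is no change at the digits printed from compound 1 to compound 2 (within the scatter), which stayed within the scatter when a different group was put on the same aromatic carbon. With no step beyond the scatter seen there, no change beyond the scatter is expected in this assay for this replacement either. For compound 3 the expected value in this assay is 100 mg/kg, with a range from 50 mg/kg to 200 mg/kg. That estimate amounts to a step of no change at the digits printed from compound 1 to compound 3 (within the scatter), expected to lie within the scatter.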

Compound 3, minimum effective dose: 300 mg/kg
Estimate against measurement, compound 3: 3.0-fold (0.48 log units) below; measured number above the stated range.
By their numbers in this assay, from the lowest: compounds 1 and 2 (each within the scatter of the next); then compound 3.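

In this assay, this aromatic carbon turns out not to be indifferent to what it carries: putting dimethylamino in place of methyl gives a 3.0-fold higher number from compound 1 to compound 3 (0.48 log units; beyond the scatter), and putting it in place of methoxy gives a 3.0-fold higher number from compound 2 to compound 3 (0.48 log units; beyond the scatter). Both steps are modest, but they point the same way: on this read-out, compound 3 shows its effect only at a larger dose than either compound 1 or compound 2, whereas the exchange of methyl for methoxy had given no change at the digits printed from compound 1 to compound 2 (within the scatter). The position, para to a large group, therefore tolerates some replacements without a visible shift but not all of them, and nothing in the data shown bears on the reason for this difference.

The compounds shown leave open whether the shift goes with the nitrogen of dimethylamino or with the size of the group, a question that an unsubstituted amine and an isopropyl group on the same carbon would help to separate. They also leave open whether any group here, such as chlorine or a carboxylic acid, would bring the number lower than that of compound 1.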